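Working notes: methoxy in place of methyl, compound 4

The source may hold more compounds than are shown below. What is called first, only, known or untested is meant among the compounds shown, and "the series" means these compounds.

Measured in a functional assay on HeLa cells (Homo sapiens) for antiproliferative activity, read by MTT assay, with a stated time of 72 h; on this read-out lower numbers stand for stronger inhibition and higher numbers for weaker inhibition:
- compound 1 `COc1cccc(N2C(=O)COc3ccc(-c4cnc5ccccc5c4)cc32)c1`: 11400 nM
- compound 2 `O=C1COc2ccc(-c3cnc4ccccc4c3)cc2N1C1CCCCC1`: 19700 nM
- compound 3 `Cc1ccc(N2C(=O)COc3ccc(-c4cnc5ccccc5c4)cc32)cc1`: > 40000 nM (a limit)

For compound 3 the reading > 40000 nM is a limit of the assay and not a number. The next structure, compound 4 `COc1ccc(N2C(=O)COc3ccc(-c4cnc5ccccc5c4)cc32)cc1`, differs from it by methoxy in place of methyl on an aromatic carbon. This is methoxy in place of methyl on an aromatic carbon, para to a large group, or 4-methylphenyl to 4-methoxyphenyl.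

For the measured compounds named here, no measured step covers this swap alone. The closest is an at least 3.5-fold higher number from compound 1 to compound 3 (0.54 log units; beyond the scatter). The other two bear on it less: an at least 2.0-fold higher number from compound 2 to compound 3 (0.30 log units; that floor lies within the scatter), and a 1.7-fold higher number from compound 1 to compound 2 (0.24 log units; within the scatter). With 3-methoxyphenyl, compound 1 gives 11400 nM, so a modest move toward lower numbers is expected in this assay, no larger than that closest step. Compound 4 may also end at a limit. The estimated step is an at least 1.6-fold lower number from compound 3 to compound 4 (0.20 log units; that floor lies within the scatter). For compound 4 the expected value is 25000 nM, with an estimated range of 10000 nM to 55000 nM.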

Compound 4, half-maximal inhibitory concentration: > 40000 nM
Compound 4 was reported as a limit (the forecaster's own chance of this, stated with the estimate: 35%); middle value at least 1.6-fold (0.20 log units) from the limit.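

Compound 4, like compound 3, gives a limit and not a number in this assay: the limit of > 40000 nM in this assay, at which 2 of the 4 values shown sit. The step from methyl to methoxy at this position therefore cannot be read, and methoxy on the 4-position of the phenyl ring does not by itself bring the value down to a measurable number. With methoxy present in both compounds, 4-methoxyphenyl in place of 3-methoxyphenyl gives an at least 3.5-fold higher number from compound 1 to compound 4 (0.54 log units; beyond the scatter), so the place of this group on the phenyl ring counts in this pair, while 4-methoxyphenyl in place of cyclohexyl gives an at least 2.0-fold higher number from compound 2 to compound 4 (0.30 log units; that floor lies within the scatter).

Going by these compounds, how far compound 3 and compound 4 lie past the limit stays open. On these data alone, it is also open whether 3-methylphenyl, or an amine in the place of the methoxy of compound 1, would give a measurable number.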